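Fluorosulfonyloxy replacing propanoyl on the chromene core

The source may report more compounds than this note shows. Statements on the series, on what has been measured and on what is new or still open speak of the compounds shown alone.

In a functional assay (aorta) with Rattus norvegicus as the target (a lower number here means a less potent compound, a higher number a more potent compound, by a factor of ten per unit of this negative logarithm), compound 1 `CCC(=O)c1ccc2c(c1)C(n1ccccc1=O)=CC(C)(C)O2` gives 6.63, the highest of the three numbers, though compound 2 `CC1(C)C=C(n2ccccc2=O)c2cc(C(=O)c3ccco3)ccc2O1` with 6.49 is not separable from it, since the step of a number 0.14 log units lower from compound 1 to compound 2 (within the scatter) stays within the scatter. Compound 3 `CC1(C)C=C(n2ccccc2=O)c2cc(OC(=O)Nc3ccc(F)cc3)ccc2O1` gives 5.3, which is well below compound 1.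

Compound 4 `CC1(C)C=C(n2ccccc2=O)c2cc(OS(=O)(=O)F)ccc2O1` differs from compound 1 in one place: (fluorosulfonyl)oxy in place of propanoyl on an aromatic carbon. For the measured compounds named here, the change at the carbonyl carbon in compound 2 left this assay unmoved, but compound 4 removes the carbonyl altogether, and the only compound without the propanoyl ketone, compound 3, sits far lower. Going by the values given here, a downward step is therefore expected, though not a firm one, since no measured pair covers this exact change. For compound 4 the estimate in this assay is 5.7, ranging from 5 to 6.4, corresponding to an expected step of a number 0.93 log units lower from compound 1 to compound 4 (beyond the scatter).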

Compound 4, logarithm of the reciprocal of the active concentration, log(1/C): 7.95
Estimate against measurement, compound 4: 2.25 log units below; measured number outside the range, above it.
By their numbers in this assay, from the lowest: compound 3; then compounds 2 and 1 (each within the scatter of the next); then compound 4.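

In this assay this aromatic carbon does not need a ketone: (fluorosulfonyl)oxy gives a number 1.32 log units higher from compound 1 to compound 4 (beyond the scatter) in place of propanoyl, and a number 1.46 log units higher from compound 2 to compound 4 (beyond the scatter) in place of (furan-2-yl)carbonyl. An oxygen on the aromatic ring does not alone set the level: fluorosulfonyl in place of (4-fluorophenyl)carbamoyl on that oxygen gives a number 2.65 log units higher from compound 3 to compound 4 (beyond the scatter) as the largest step in the series. No measurement at hand accounts for this rise. Still open, on these data alone, is whether the fluorine is needed for the rise; methanesulfonyloxy or a hydroxyl on this aromatic carbon would test that.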